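The source may report more compounds than this note shows. Statements on the series, on what has been measured and on what is new or still open speak of the compounds shown alone.

Measured so far:
compound 1, `CCCCCCCCS(=O)(=O)Nc1ccc(-c2cccc(Cl)c2)cc1C(=O)O`, 8900 nM in an assay on mitochondria (strain BALB/c) for inhibition of glycerol-3-phosphate acyltransferase 1, mitochondrial (Mus musculus), read by scintillation counting, with a stated time of 10 min; on this read-out higher numbers stand for weaker inhibition and lower numbers for stronger inhibition;
compound 2, `CCCCCCCCS(=O)(=O)Nc1ccc(-c2ccccc2F)cc1C(=O)O`, 34600 nM in this assay.

Compound 2 holds the highest of the two numbers measured in this assay; its nearest neighbour is compound 1, and the step of a 3.9-fold higher number from compound 1 to compound 2 (0.59 log units; beyond the scatter) lies beyond the scatter, with a 2-fluorophenyl in place of a 3-chlorophenyl on an aromatic carbon. Compound 3, `CCCCCCCCS(=O)(=O)Nc1ccc(-c2cccc(F)c2)cc1C(=O)O`, has not been measured yet. It differs from compound 2 in one place: 3-fluorophenyl in place of 2-fluorophenyl on an aromatic carbon, sitting on an aromatic carbon of a six-membered aromatic ring of carbon only, meta to a carboxy group and para to a large group. Among the measured compounds shown here, only the step from compound 1 to compound 2 bears on this, and it is an imperfect guide, since it changes both the halogen and where it sits. Compound 1 carries its chlorine in the same 3-position that the fluorine of compound 3 takes, and compound 1 gave the lower number. The expected step is therefore a 2.2-fold lower number from compound 2 to compound 3 (0.33 log units; beyond the scatter), downward but modest. Compound 3 is estimated at 16000 nM in this assay, within a range from 6000 nM to 40000 nM.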

Compound 3, half-maximal inhibitory concentration: 37600 nM
Compound 3: the middle estimate sits 2.4-fold (0.37 log units) below what was measured; the range from low to high includes it.
By their numbers in this assay, from the lowest: compound 1; then compounds 2 and 3 (each within the scatter of the next).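

Placing the fluorine as in the 3-fluorophenyl rather than the 2-fluorophenyl group gives a 1.1-fold higher number from compound 2 to compound 3 (0.04 log units; within the scatter), so in this assay these two fluorophenyl compounds cannot be told apart, and for fluorine this change of place has no readable effect on the number. The comparison of compound 1 with compound 3 keeps the halogen on the same carbon and changes only the halogen itself, which the earlier pair could not do; fluoro in place of chloro gives a 4.2-fold higher number from compound 1 to compound 3 (0.63 log units; beyond the scatter), so at this position the choice of halogen shows up in the number, while the earlier step mixed halogen and place. Nothing measured in this set accounts for this difference between chloro and fluoro.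

The compounds shown leave open whether moving a chlorine rather than a fluorine would also leave the number unchanged, and whether a bromo group, a methyl group or a plain phenyl ring with no halogen would follow chloro or fluoro. They also leave open whether the same difference between the two halogens holds with a different chain on the sulfonyl group, such as a decyl chain.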